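The source may report more compounds than this note shows. Statements on the series, on what has been measured and on what is new or still open speak of the compounds shown alone.

Compound 1 `O=c1cc(CNCc2ccccc2O)oc2ccc(O)c(O)c12`: > 100000 nM
Compound 2 `O=c1cc(CNCc2cccc(Cl)c2)oc2ccc(O)c(O)c12`: > 100000 nM
Compound 3 `O=c1cc(CNCc2cccc(Br)c2)oc2ccc(O)c(O)c12`: not yet measured

In an ADME assay on Huh-7 cells (Homo sapiens) for cytotoxicity (on this read-out higher numbers stand for lower toxicity in this test and lower numbers for higher toxicity in this test), compound 1 gives only the limit of the assay, > 100000 nM. Compound 2 likewise gives only the limit, > 100000 nM. Both values sit at the same limit (the limit of > 100000 nM in this assay, at which 2 of the 2 values shown sit), so the step that the two limits leave unreadable from compound 1 to compound 2 cannot be read as a number. Compound 2 therefore stands at the limit of the assay, with no number of its own to compare against. Compound 3 differs from compound 2 by bromo in place of chloro on an aromatic carbon. Going by the values given here, the one measured step concerns a different exchange and its size is not readable, so it offers no direction for the coming step. The expected step is a step that the limit leaves unreadable from compound 2 to compound 3, no size beyond the scatter. Compound 3 is expected to give 150000 nM, within 50000 nM to 500000 nM, most likely again as a limit rather than a number.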

Compound 3, half-maximal cytotoxic concentration: > 100000 nM
Compound 3: a limit, no number (the forecaster's own chance of this, stated with the estimate: 85%); the middle value is on the limit's open side.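

Compound 3 also gives only a limit, > 100000 nM. Going by these compounds alone, no step among compound 1, compound 2 and compound 3 can therefore be read as a size: the limit of > 100000 nM in this assay, at which 3 of the 3 values shown sit. None of these compounds has a number of its own, so whether they differ at all in this assay stays open.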